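Triazole side-chain variation and cytotoxicity in the series

The source may report more compounds than this note shows. Statements on the series, on what has been measured and on what is new or still open speak of the compounds shown alone.

Compound 3 `COC(=O)Cn1cc(CNC(=O)c2cnc(Nc3ccc(C#N)cc3)cc2Oc2c(C)cc(C)cc2C)nn1` stands second highest of the three numbers in an ADME assay on MT4 cells (Homo sapiens) for cytotoxicity, read by MTT assay, with a stated time of 5 days (on this read-out higher numbers stand for lower toxicity in this test and lower numbers for higher toxicity in this test), where compound 3 gives 13800 nM. Nearest is compound 2 `CCOC(=O)Cn1cc(CNC(=O)c2cnc(Nc3ccc(C#N)cc3)cc2Oc2c(C)cc(C)cc2C)nn1`, which gives 9530 nM; the step of a 1.4-fold higher number from compound 2 to compound 3 (0.16 log units; within the scatter) lies within the scatter. Furthest is compound 1 `Cc1cccc(Cn2cc(CNC(=O)c3cnc(Nc4ccc(C#N)cc4)cc3Oc3c(C)cc(C)cc3C)nn2)c1`, which gives 114000 nM, with an 8.3-fold lower number from compound 1 to compound 3 (0.92 log units; beyond the scatter) and a 12-fold lower number from compound 1 to compound 2 (1.08 log units; beyond the scatter). Compound 4 `Cc1cc(C)c(Oc2cc(Nc3ccc(C#N)cc3)ncc2C(=O)NCc2cn(CCCO)nn2)c(C)c1` is not yet measured; the change 2-hydroxyethyl in place of methoxycarbonyl on a saturated chain carbon bound to an aromatic nitrogen sits on a saturated chain carbon bound to an aromatic nitrogen, the same place as both steps from compound 1. Among the measured compounds shown here, no measured step exchanges methoxycarbonyl for 2-hydroxyethyl, so direction rests on analogy: both large moves followed a change at that place, whereas the two carbonyl-bearing chains did not separate. Compound 4 is expected to give 25000 nM in this assay, with a range from 8000 nM to 90000 nM. The expected step is a 1.8-fold higher number from compound 3 to compound 4 (0.26 log units; within the scatter), uncertain in size.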

Compound 4, half-maximal cytotoxic concentration: 25200 nM
For compound 4 the middle estimate is 1.0-fold (0.00 log units) below the measured one; low and high end bracket the measured number.
By their numbers in this assay, from the lowest: compounds 2, 3 and 4 (each within the scatter of the next, the first and the last beyond it); then compound 1.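

At the saturated chain carbon bound to an aromatic nitrogen, in this assay 2-hydroxyethyl in place of methoxycarbonyl gives no step beyond the scatter (a 1.8-fold higher number from compound 3 to compound 4 (0.26 log units; within the scatter)). In place of ethoxycarbonyl, the same group does give a step beyond the scatter (a 2.6-fold higher number from compound 2 to compound 4 (0.42 log units; beyond the scatter)), and compound 1 with 3-methylphenyl stays apart (a 4.5-fold lower number from compound 1 to compound 4 (0.66 log units; beyond the scatter)), so only the aromatic chain has clearly separated from the other three. No evidence bears on the cause of these differences. Still open, from the compounds shown here alone, is how a carboxylic acid, an amine or a longer hydroxyalkyl chain would read at this place.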